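The source may report more compounds than this note shows. Statements on the series, on what has been measured and on what is new or still open speak of the compounds shown alone.

Working notes on a urea series built on the shared core of compound 1 `Cc1cc(NC(=O)Nc2ccc(C(C)(C)C)cc2)c2ccccc2n1`. In an ADME assay on HEK293 cells (Homo sapiens) for cytotoxicity, with a stated time of 72 h (on this read-out higher numbers stand for an effect only at larger amounts of compound and lower numbers for an effect already at smaller amounts), compound 1 gives > 25000 nM, which is a limit of the assay and not a number. Compound 2 `Cc1cc(NC(=O)Nc2ccccc2C(C)(C)C)c2ccccc2n1` is the second measured member of the series. In this assay compound 2 gives > 25000 nM, likewise a limit rather than a number. Everything measured so far reduces to the limit of > 25000 nM in this assay, at which 2 of the 2 values shown sit; compound 1 therefore stands at the limit, with no value in the set lying anywhere else, and no step between measured compounds can be counted. Compound 3 `Cc1cc(NC(=O)Nc2ccc(C(N)=O)cc2)c2ccccc2n1` is the next member to be measured in this assay. It differs from compound 1 in a single place: carbamoyl in place of tert-butyl on an aromatic carbon. Among the measured compounds shown here, with no measured step to lean on, the expectation rests only on the two limits. The step expected is a step that the limit leaves unreadable from compound 1 to compound 3, that is none beyond the usual scatter, since both measured compounds sit at the limit. For compound 3 the expected value in this assay is 30000 nM, with a range from 15000 nM to 60000 nM.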

Compound 3, half-maximal effective concentration: > 25000 nM
Compound 3: no number, only a limit; the forecaster's own chance of this, stated with the estimate: 80%; the middle value is on the limit's open side.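

In this assay no step can be read from compound 1 to compound 3, as both values are limits and not numbers. The compounds shown leave open whether any member of the series gives an actual number in this read-out, and how carbamoyl compares with tert-butyl, since all that stands is one shared value: the limit of > 25000 nM in this assay, at which 3 of the 3 values shown sit.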